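Chloro Substitution on a Benzoxazole Anilide Series

The source may report more compounds than this note shows. Statements on the series, on what has been measured and on what is new or still open speak of the compounds shown alone.

Measured compounds:
compound 1, `Cc1cc(-c2nc3cc(Cl)ccc3o2)ccc1NC(=O)CN1CCN(CCCN(C)C)CC1`, 11200 nM
compound 2, `Cc1cc(-c2nc3ccccc3o2)ccc1NC(=O)CN1CCN(CCCN(C)C)CC1`, 2160 nM
compound 3, `Cc1cc(-c2nc3ccccc3o2)ccc1NC(=O)CCl`, 14800 nM

Of the compounds shown here, three have been measured in a functional assay on HepG2 cells (Homo sapiens) for cytotoxicity, read by MTT assay, with a stated time of 24 h; a lower number here means a stronger inhibitor, a higher number a weaker inhibitor. Compound 2 gives 2160 nM, and compound 1 gives 11200 nM. The two differ in one place: chloro in place of hydrogen on an aromatic carbon. That change produced a 5.2-fold higher number from compound 2 to compound 1 (0.71 log units; beyond the scatter).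

Compound 3 carries a chloroacetamide in place of the piperazine-bearing chain, and in this assay compound 3 gives 14800 nM. The difference between the core of compound 3 and the core of compound 2 is not broken down here. Its number stands close to that of compound 1, within the usual scatter, while compound 2 sits well apart from both.

Compound 4, `Cc1cc(-c2nc3cc(Cl)ccc3o2)ccc1NC(=O)CCl`, has not yet been measured. Relative to compound 3 it carries the same change seen between compound 2 and compound 1: chloro in place of hydrogen on an aromatic carbon. Among the measured compounds shown here, with only one earlier instance of this change, the expectation rests on the single step of a 5.2-fold higher number from compound 2 to compound 1 (0.71 log units; beyond the scatter). Applied to compound 3, a step of about a 3.0-fold higher number from compound 3 to compound 4 (0.48 log units; beyond the scatter) is expected, tempered toward a smaller move because compound 3 already gives 14800 nM and because the change has been seen only once in a 5.2-fold higher number from compound 2 to compound 1 (0.71 log units; beyond the scatter) and may not carry over fully. Compound 4 is therefore estimated at 45000 nM, with a range of 15000 nM to 120000 nM.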

Compound 4, half-maximal inhibitory concentration: 35000 nM
Beside the measured number, compound 4's estimate is 1.3-fold (0.11 log units) above it, within the range that was stated.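

In this assay, chloro in place of hydrogen on an aromatic carbon again gave a higher number, a weaker result, with a 2.4-fold higher number from compound 3 to compound 4 (0.37 log units; beyond the scatter), so the change moved the number in the same direction on both cores shown. The two steps differ in their printed size, but that gap does not separate them: the same change on two cores in this assay, a 5.2-fold higher number (0.71 log units; beyond the scatter) from compound 2 to compound 1 and a 2.4-fold higher number (0.37 log units; beyond the scatter) from compound 3 to compound 4, 2.2-fold (0.34 log units) apart, within the scatter of two such steps. This shows that, across these two pairs, the change carried over from the core bearing the piperazine chain to the chloroacetamide core in direction and, within the scatter, in size, but two pairs do not show that it would hold on any further core, and they do not show what lies behind the step.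

The compounds shown leave open whether fluoro, methyl or methoxy in place of hydrogen at that same aromatic carbon would give a step like the one seen with chloro. They also leave open whether the chloro step would persist if a morpholine, a simple amine or a carboxylic acid stood in place of the piperazine-bearing chain or the chloroacetamide.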